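The source may hold more compounds than are shown below. What is called first, only, known or untested is meant among the compounds shown, and "the series" means these compounds.

In a functional assay on HeLa cells (Homo sapiens) for antiproliferative activity, read by MTT assay, with a stated time of 72 h (on this read-out higher numbers stand for weaker inhibition and lower numbers for stronger inhibition), compound 1 (`N=C(NS(=O)(=O)c1ccccc1)N1CCN(c2cc3c(cc2F)c(=O)c(C(=O)O)cn3C2CC2)CC1`) gives 32 nM, and it stands level with compound 2 (`Cc1ccc(S(=O)(=O)NC(=N)N2CCN(c3cc4c(cc3F)c(=O)c(C(=O)O)cn4C3CC3)CC2)cc1`) at 32 nM and compound 3 (`N=C(NS(=O)(=O)c1ccc(Cl)cc1)N1CCN(c2cc3c(cc2F)c(=O)c(C(=O)O)cn3C2CC2)CC1`) at 32 nM in this small series. Compound 4 (`N=C(NS(=O)(=O)c1ccccc1C(F)(F)F)N1CCN(c2cc3c(cc2F)c(=O)c(C(=O)O)cn3C2CC2)CC1`) is still unmeasured. It differs from compound 1 by trifluoromethyl in place of hydrogen on an aromatic carbon, which turns phenyl into 2-(trifluoromethyl)phenyl (trifluoromethyl in place of hydrogen on an aromatic carbon). The new group sits ortho to a large group.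

Among the measured compounds shown here, two measured steps bear on this change, both replacing hydrogen on the same aromatic ring. Methyl gave no change at the digits printed from compound 1 to compound 2 (within the scatter) and chloro gave no change at the digits printed from compound 1 to compound 3 (within the scatter), while the swap of chloro for methyl gave no change at the digits printed from compound 2 to compound 3 (within the scatter). None of these steps places a group ortho to a large group, and none involves trifluoromethyl, so they cover the new change only in part. No shift beyond the scatter is expected, and no direction is favoured, so the expected result is no change at the digits printed from compound 1 to compound 4 (within the scatter) in this assay. Compound 4 is estimated at 32 nM, with an expected range from 14 nM to 75 nM.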

Compound 4, half-maximal inhibitory concentration: 32 nM
Compound 4: middle estimate and measured number agree at the digits printed; the range from low to high includes it.
By their numbers in this assay, from the lowest: compounds 1, 2, 3 and 4 (each within the scatter of the next).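

In this assay the series now includes a substituent ortho to a large group, and trifluoromethyl gives no change at the digits printed from compound 1 to compound 4 (within the scatter) in this position. Exchanging the whole aryl group on the sulfonyl sulfur gives the same reading, with no change at the digits printed from compound 3 to compound 4 (within the scatter) and no change at the digits printed from compound 2 to compound 4 (within the scatter), so 2-(trifluoromethyl)phenyl stays level with 4-chlorophenyl and 4-methylphenyl in this series. No available evidence bears on this level result.

Going by these compounds, whether the read-out stays level with an amine or a carboxylic acid on this ring, or with a longer alkyl chain in place of the ring on the sulfonyl sulfur, remains open. On these data alone, whether these four compounds also stay level on cells other than HeLa remains open too.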